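The source may report more compounds than this note shows. Statements on the series, on what has been measured and on what is new or still open speak of the compounds shown alone.

The measured compounds in an assay on isolated protein for displacement of a labelled ligand from metabotropic glutamate receptor 5 (Homo sapiens), with a stated time of 60 min, tested at 1 uM; a higher number here means more inhibition at the concentration tested (going by the name of the read-out), a lower number less inhibition:
compound 1 `CCOC(=O)C1CCN(c2c(S(=O)(=O)c3ccccc3)cnc3ccccc23)CC1` gives 33%;
compound 2 `Cc1cc(C)cc(S(=O)(=O)c2cnc3cc(F)ccc3c2N2CCC(C)CC2)c1` gives 80%;
compound 3 `Cc1ccc(S(=O)(=O)c2cnc3ccc(Cl)cc3c2N2CCC(C)CC2)cc1F` gives 68%.

Compound 2 stands highest of the three numbers. Its nearest neighbour is compound 3, whose reading lies lower by a gap that is beyond the usual scatter, and the furthest is compound 1, whose reading lies lower by a much larger gap, also beyond the scatter. Among the compounds with values here, no two of the measured compounds differ in a single place, so no counted step between them is available, and the account turns to an unmeasured compound instead.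

Compound 4 `CC1CCN(c2c(S(=O)(=O)c3cccc(C#N)c3)cnc3cc(F)ccc23)CC1` differs from compound 2 by 3-cyanophenyl in place of 3,5-dimethylphenyl on a sulfonyl sulfur. Within the data shown here, nothing among the measured compounds changes only this one place, so the other two compounds offer no direct guide; each of them differs from compound 2 in more than one place at once. The expectation for this step is a drop of moderate size, beyond the scatter but leaving compound 4 well clear of the lowest reading, as estimated in a number 25 percentage points lower from compound 2 to compound 4 (beyond the scatter). Compound 4 is thus expected to reach 55% in this assay, within an estimated range from 25% to 80%.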

Compound 4, a percentage reported as inhibition, at one concentration (the size of the read-out at that concentration, not a potency): 92%
Estimate against measurement, compound 4: 37 percentage points below; the measured number lies above the stated range.
By their numbers in this assay, from the lowest: compound 1; then compound 3; then compound 2; then compound 4.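

Within the data shown here, the change of 3,5-dimethylphenyl to 3-cyanophenyl on a sulfonyl sulfur is the only change in this set that can be read on its own, and in this assay it gives a number 12 percentage points higher from compound 2 to compound 4 (beyond the scatter). A high reading at this place therefore does not depend on the 3,5-dimethylphenyl group: with a nitrile on the ring and the rest of the molecule unchanged, compound 4 gives 92%, and the entering group counts one hydrogen-bond acceptor where the leaving group counts none. The data at hand offer nothing that explains why the reading rises with this change.

A single step cannot show whether the nitrile itself matters, or whether a methoxy group, a chlorine atom or an amine carried on the same ring would read the same way, and it cannot show whether the same change would raise the readings of compound 1 and compound 3, whose other parts differ. Going by these compounds, these are also readings at one concentration and not potencies, so how far compound 2 and compound 4 differ in potency remains open.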